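A few compounds are considered here, and "the series" means these few. Any claim that something is new, unique, unknown or untested is made for them only; others in the source may bear on it.

Among the measured compounds shown here, compound 1, `COc1nc(N[C@H](CCC(=O)O)C(=O)O)nc(OC)n1`, is the only member of this small set with a number attached to it: in an assay for inhibition of Pro-cathepsin H (Homo sapiens), read by fluorescence, tested at 50 uM (on this read-out lower numbers stand for less inhibition and higher numbers for more inhibition at the one concentration tested (going by the name of the read-out)), compound 1 gives 0.34%, which sits at the low end of the scale. Compound 2, `O=c1nc(SCc2ccccc2)nc(SCc2ccccc2[N+](=O)[O-])[nH]1`, has no result in this assay; for compound 2 the record reads "not determined" (no result reported). Compound 3, `N#Cc1cccc(CSc2nc(SCc3ccccc3)nc(=O)[nH]2)c1`, is in the same position: for compound 3 the entry in this assay is "not determined" (no result reported), so nothing can be said about where compound 3 stands among the numbers beyond the fact that it has none.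

Compound 4, `O=c1nc(SCc2ccccc2)nc(SCC2CCC2)[nH]1`, has not yet been tested. It differs from compound 3 in one place, (cyclobutyl in place of 3-cyanophenyl on a saturated chain carbon bound to a sulfur). Two aromatic ring atoms bearing a nitrile give way to a small saturated ring on the same chain carbon bound to sulfur.

For the measured compounds named here, with no measured step between any two compounds in this assay, and no number for compound 3, there is nothing to scale the change against. The expectation for the step in this assay is therefore none beyond the usual scatter, with no direction to lean toward. Going by the values given here, on that basis, and taking the one recorded number as the only anchor, compound 4 is estimated at 5% in this assay, expected to fall between 0% and 25%.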

Compound 4, a percentage reported as inhibition, at one concentration (the size of the read-out at that concentration, not a potency): 1.57%
Compound 4: middle estimate off by 3.4 percentage points, on the high side; measured number inside the range.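

No new step can be read between compound 3 and compound 4: in this assay compound 3 has no single number to set against the value of compound 4. No supporting evidence bears on this result. The compounds shown leave open whether exchanging 3-cyanophenyl for cyclobutyl changes inhibition at all.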